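The source may hold more compounds than are shown below. What is called first, only, known or untested is meant among the compounds shown, and "the series" means these compounds.

Measured compounds, cytotoxicity on liver-derived cells:

Compound 1 `CC(C)N(Cc1cccc(OCCCCCC(=O)O)c1)C(=O)c1ccc(-c2ccncc2)cc1` gives > 26000 nM, a limit of the assay.
Compound 2 `CC(C)COc1cccc(-c2ccc(C(=O)N(Cc3cccc(OCCCCCC(=O)O)c3)C(C)C)cc2)c1` gives > 26000 nM, a limit of the assay.
Compound 3 `Cc1nnc(-c2cccc(-c3ccc(C(=O)N(Cc4cccc(OCCCCCC(=O)O)c4)C(C)C)cc3)c2)o1` gives > 26000 nM, a limit of the assay.

In an ADME assay on HepG2 cells (Homo sapiens) for cytotoxicity, read by CellTiter-Glo and resazurin assay, with a stated time of 72 h (a higher number here means that more compound is needed for the effect, a lower number that less compound is needed), compound 3 stands where the other two stand: every value recorded for the series is a limit and no number, as the limit of > 26000 nM in this assay, at which 3 of the 3 values shown sit, shows. The steps among the measured compounds are therefore unreadable: a step that the two limits leave unreadable from compound 1 to compound 2, a step that the two limits leave unreadable from compound 1 to compound 3 and a step that the two limits leave unreadable from compound 2 to compound 3 all sit between two limits and give no size.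

The next compound to be measured is compound 4 `CC(C)N(Cc1cccc(OCCCCCC(=O)O)c1)C(=O)c1ccc(-c2ccc(Cl)c(Cl)c2)cc1`. It differs from compound 3 by 3,4-dichlorophenyl in place of 3-(5-methyl-1,3,4-oxadiazol-2-yl)phenyl on an aromatic carbon.

The measured steps that bear on this change are those of the biaryl terminus, and none of them gives a readable size; the three compounds vary that terminus widely without any of them reaching a number. No step beyond the scatter is therefore expected in this assay; the step that the limit leaves unreadable from compound 3 to compound 4 is an estimate anchored on the limit, not on a measured change. Compound 4 is expected to give about 30000 nM, with a range from 10000 nM to 80000 nM, most likely again reported as a limit.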

Compound 4, half-maximal effective concentration: > 26000 nM
Compound 4: no number, only a limit; the forecaster's own chance of this, stated with the estimate: 65%; the middle value does not contradict the limit.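

Compound 4 gives > 26000 nM in this assay, a limit of the assay. No step between compound 4 and compound 1, compound 2 or compound 3 can be read: the limit of > 26000 nM in this assay, at which 4 of the 4 values shown sit.

The compounds shown leave open whether any group at this place would give a number rather than a limit in this assay.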